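Swapping thiophene for furan on a glycosylated oxindole series

This account rests on a few compounds, and the source may have more. Where it says the series, first, only, none or still open, it means among the compounds named here.

Measured compounds:
- Compound 1 `CC(=O)OC[C@H]1O[C@@H](n2cc(CN3C(=O)/C(=C\c4ccccc4)c4ccccc43)nn2)[C@H](OC(C)=O)[C@@H](OC(C)=O)[C@@H]1OC(C)=O`: 17900 nM
- Compound 2 `CC(=O)OC[C@H]1O[C@@H](n2cc(CN3C(=O)/C(=C\C=C\c4ccccc4)c4ccccc43)nn2)[C@H](OC(C)=O)[C@@H](OC(C)=O)[C@@H]1OC(C)=O`: 58400 nM
- Compound 3 `CC(=O)OC[C@H]1O[C@@H](n2cc(CN3C(=O)/C(=C\c4cccs4)c4ccccc43)nn2)[C@H](OC(C)=O)[C@@H](OC(C)=O)[C@@H]1OC(C)=O`: 16100 nM

All three compounds share one core, a sugar-bearing triazole linked to an oxindole carrying an exocyclic double bond; they differ only in the group on that double-bonded chain carbon. In a functional assay on A549 cells (Homo sapiens) for cytotoxicity, read by sulforhodamine B assay, with a stated time of 48 h (on this read-out lower numbers stand for stronger inhibition and higher numbers for weaker inhibition), compound 3 gives the lowest number of the three, yet compound 1 lies within the scatter of it, so the two cannot be told apart, and only compound 2 stands clearly apart, as shown by a 3.6-fold lower number from compound 2 to compound 3 (0.56 log units; beyond the scatter).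

Compound 4 `CC(=O)OC[C@H]1O[C@@H](n2cc(CN3C(=O)/C(=C\c4ccco4)c4ccccc43)nn2)[C@H](OC(C)=O)[C@@H](OC(C)=O)[C@@H]1OC(C)=O` is the unmeasured analogue; here the change is furan-2-yl in place of thiophen-2-yl on a double-bonded chain carbon bound to a double-bonded ring carbon. The most relevant precedent is the comparable heteroaryl-for-aryl swap, a 1.1-fold lower number from compound 1 to compound 3 (0.05 log units; within the scatter), which stayed within the scatter. Among the measured compounds shown here, the only larger step, a 3.3-fold higher number from compound 1 to compound 2 (0.51 log units; beyond the scatter), came from lengthening the chain, not from exchanging one ring for another of the same size. With a single five-membered ring replaced by another of equal size, the expected change in this assay is none beyond the scatter, so a 1.0-fold lower number from compound 3 to compound 4 (0.00 log units; within the scatter) is the estimated step. Compound 4 is therefore expected to give about 16000 nM, within a range of 6000 nM to 45000 nM.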

Compound 4, half-maximal inhibitory concentration: 41100 nM
Beside the measured number, compound 4's estimate is 2.6-fold (0.41 log units) below it; the range from low to high includes it.
By their numbers in this assay, from the lowest: compounds 3 and 1 (each within the scatter of the next); then compounds 4 and 2 (each within the scatter of the next).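

In this assay this position separates two five-membered aromatic rings that each carry one hetero atom: exchanging sulfur for oxygen gives a 2.6-fold higher number from compound 3 to compound 4 (0.41 log units; beyond the scatter), whereas the earlier exchange of phenyl for thiophen-2-yl stayed within the scatter. Furan-2-yl also stands apart from phenyl, with a 2.3-fold higher number from compound 1 to compound 4 (0.36 log units; beyond the scatter), but not from the longer 2-phenylethenyl group, with a 1.4-fold lower number from compound 2 to compound 4 (0.15 log units; within the scatter), so exchanging one ring for another, and not only lengthening the chain, can move the number beyond the scatter here. Nothing available explains the difference between the two rings.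

Going by these compounds, it remains open whether a pyridin-2-yl ring, or a phenyl ring bearing a carboxylic acid, would fall with compound 1 and compound 3 or with compound 2 and compound 4. The compounds shown also leave open whether the furan-2-yl and thiophen-2-yl groups would still differ with hydroxyl groups in place of the acetyl esters on the sugar.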